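Amide variation in a paw-edema series: working notes

The source may report more compounds than this note shows. Statements on the series, on what has been measured and on what is new or still open speak of the compounds shown alone.

Measured so far in a functional assay on the whole organism (strain Wistar) for inhibition, with Rattus norvegicus as the target, read by paw edema, with stated times of 60 min and 2 h, at a dose of 100 mg/kg by the oral route; a lower number here means less inhibition, a higher number more inhibition at the dose given (going by the name of the read-out):
compound 1 `COc1cc2c(cc1OC)C(CC(=O)N(C)C)CC2`: 36%
compound 2 `CCNC(=O)CC1CCc2cc(OC)c(OC)cc21`: 26%

Compound 1 holds the higher of the two numbers in this assay, but its nearest neighbour is compound 2, and the step of a number 10 percentage points lower from compound 1 to compound 2 (within the scatter) is within the scatter, so the two measured compounds cannot be ordered against each other. Among the compounds with values here, the only structural step measured so far is that from compound 1 to compound 2, ethylamino in place of dimethylamino on a carbonyl carbon, and it moved the read-out by no more than repeated measurements would.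

Compound 3 `COc1cc2c(cc1OC)C(CC(=O)NCc1ccccc1)CC2` has not yet been measured in this assay. Relative to compound 1 the change is benzylamino in place of dimethylamino on a carbonyl carbon. On these data alone, the step from compound 1 to compound 2 bears on it in that both exchange the dimethylamino for a group carrying one hydrogen-bond donor; that step was within the scatter, so for compound 3 no shift beyond the scatter is expected in either direction, though the benzylamino group itself is untested and the range is left wide. Compound 3 is therefore estimated at 30%, between 10% and 50%, which means an expected step of a number 6 percentage points lower from compound 1 to compound 3 (within the scatter).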

Compound 3, a percentage reported as inhibition, in the whole organism at one dose (the size of the read-out at that dose, not a potency): 24%
The estimate for compound 3 lay 6 percentage points above the measured number; low and high end bracket the measured number.
By their numbers in this assay, from the lowest: compounds 3, 2 and 1 (each within the scatter of the next, the first and the last beyond it).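

In this assay, within the data shown here, the benzylamino exchange gives the first step at this carbonyl carbon that can be told from the scatter: a number 12 percentage points lower from compound 1 to compound 3 (beyond the scatter). The read-out at this dose therefore does respond to the amine part of the amide, though the size of the response is small and rests on one pair. The ethylamino group does not separate from either neighbour, and phenyl in place of methyl on a saturated chain carbon bound to an amide-type nitrogen gives a number 2 percentage points lower from compound 2 to compound 3 (within the scatter), so the larger benzylamino group cannot be told from ethylamino here, and compound 2 sits within the scatter of both compound 1 and compound 3. Nothing available bears on why the read-out moved at this position.

The compounds shown leave open whether the lower number of compound 3 goes with the amide hydrogen, with the aromatic ring of the benzylamino group, or with both, as the two arrive together in this one exchange. A piperidine amide, which has a ring but no amide hydrogen, or a carboxylic acid in place of the amide, would test this position further.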